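Carboxy in Place of Hydroxymethyl on a Second Core

A few compounds are considered here, and "the series" means these few. Any claim that something is new, unique, unknown or untested is made for them only; others in the source may bear on it.

Compound 1 `CCCCc1nc(Cl)c(CO)n1Cc1ccc(C2=C(c3nn[nH]n3)CCC2)cc1` gives 3.78 in a physicochemical assay for lipophilicity; a lower number here means a more polar compound, a higher number a more lipophilic compound.
Compound 2 `CCCCc1nc(Cl)c(CO)n1Cc1ccc(C2=C(c3nn[nH]n3)CCCC2)cc1` gives 4.34 in this assay.
Compound 3 `CCCCc1nc(Cl)c(C(=O)O)n1Cc1ccc(C2=C(c3nn[nH]n3)CCC2)cc1` gives 4.25 in this assay.

Compound 1 and compound 2 share most of their structure, but the difference between the two cores is not broken down here. Compound 4 `CCCCc1nc(Cl)c(C(=O)O)n1Cc1ccc(C2=C(c3nn[nH]n3)CCCC2)cc1` is not yet measured. From compound 1 to compound 3 the change is carboxy in place of hydroxymethyl on an aromatic carbon, and it moved this assay by a number 0.47 log units higher from compound 1 to compound 3 (beyond the scatter). From compound 2 to compound 4 the change is carboxy in place of hydroxymethyl on an aromatic carbon, the same change at the same place. The step expected from compound 2 to compound 4 is a number 0.47 log units higher from compound 2 to compound 4 (beyond the scatter), resting on the step of a number 0.47 log units higher from compound 1 to compound 3 (beyond the scatter) seen for the same change. Compound 4 is therefore estimated at 4.81, with a likely range from 4.45 to 5.15.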

Compound 4, partition coefficient: 4.81
The estimate for compound 4 equals the measured number at the digits printed, within the range that was stated.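

In this assay carboxy in place of hydroxymethyl on an aromatic carbon gives a number 0.47 log units higher from compound 2 to compound 4 (beyond the scatter) and so matches a number 0.47 log units higher from compound 1 to compound 3 (beyond the scatter) in size, which means the change carried over unaltered between these two cores. This is one change on one pair of cores, so it sets no general rule for the series and says nothing about any other kind of assay. Nothing shown here explains why the step stayed the same size.

The compounds shown leave open whether the step would hold if a longer chain replaced the butyl group. They also leave open how an amide in place of the carboxy group would compare.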